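The source may report more compounds than this note shows. Statements on the series, on what has been measured and on what is new or still open speak of the compounds shown alone.

Compound 1 `NC1=NC2(CCSCC2)N(OCCCOc2ccc(Cl)c(Cl)c2)C(N)=N1`: 10 nM
Compound 2 `CC(C)(C)c1ccc(OCCCON2C(N)=NC(N)=NC23CCSCC3)cc1`: 1 nM

In a functional assay on MDA-MB-231 cells (Homo sapiens) for antiproliferative activity, read by MTT assay, with a stated time of 72 h (a lower number here means a stronger inhibitor, a higher number a weaker inhibitor), compound 1 gives 10 nM, the higher of the two numbers measured. Compound 2 gives 1 nM, a gap that lies beyond the scatter. Compound 3 `NC1=NC2(CCSCC2)N(OCCCOc2cccc(Cl)c2)C(N)=N1` differs from compound 1 in one place: hydrogen in place of chloro on an aromatic carbon. Among the measured compounds shown here, no measured pair shows the effect of this change, so the expected step is a small loss, from compound 1 to compound 3 an estimated 2.0-fold higher number from compound 1 to compound 3 (0.30 log units; within the scatter). For compound 3 in this assay the estimate is 20 nM, within the range 6 nM to 60 nM.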

Compound 3, half-maximal inhibitory concentration: 130 nM
Compound 3: the middle estimate sits 6.5-fold (0.81 log units) below what was measured; the whole stated range lies below it.
By their numbers in this assay, from the lowest: compound 2; then compound 1; then compound 3.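

In this assay, going from 3,4-dichlorophenyl to 3-chlorophenyl gives a 13-fold higher number from compound 1 to compound 3 (1.11 log units; beyond the scatter). This single chloro group, on the aromatic carbon para to a large group, therefore carries much of the activity of compound 1, so losing one atom is not a minor edit here. Nothing available explains why this atom matters so much.

From the compounds shown here alone, whether an amine, a methoxy group or a carboxylic acid at this position would keep that activity remains open. So does the effect of removing the other chloro group instead.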